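From benzyl to 2,4-dichlorobenzyl in compound 2

The source may report more compounds than this note shows. Statements on the series, on what has been measured and on what is new or still open speak of the compounds shown alone.

In a functional assay on MCF7 cells (Homo sapiens) for antiproliferative activity, read by MTT assay, with a stated time of 48 h (on this read-out higher numbers stand for weaker inhibition and lower numbers for stronger inhibition), compound 1 `O=[N+]([O-])c1cc(C(F)(F)F)cc([N+](=O)[O-])c1Oc1ccccc1/C=N/OCc1ccc(Cl)cc1Cl` gives 940 nM and compound 2 `O=[N+]([O-])c1cc(C(F)(F)F)cc([N+](=O)[O-])c1Oc1ccc(Cl)cc1/C=N\OCc1ccccc1` gives 1220 nM. Going by the values given here, these two values lie within the usual scatter of each other, so compound 2 stands level with compound 1 on the only numbers available. Compound 3 `O=[N+]([O-])c1cc(C(F)(F)F)cc([N+](=O)[O-])c1Oc1ccc(Cl)cc1/C=N\OCc1ccc(Cl)cc1Cl` alters compound 2 in one place: 2,4-dichlorophenyl in place of phenyl on a saturated chain carbon bound to an oxygen. A 2,4-dichlorophenyl takes the place of phenyl on a saturated chain carbon bound to an oxygen, turning benzyl into 2,4-dichlorobenzyl. Among the compounds with values here, no measured pair isolates this change. Compound 1, which also carries a 2,4-dichlorobenzyl group, reads 940 nM, so a large step in this assay is not expected. The expected step of a 1.4-fold lower number from compound 2 to compound 3 (0.16 log units; within the scatter) is small, toward stronger inhibition, and may stay within the scatter. For compound 3 the estimated value is 850 nM, with an expected range of 350 nM to 2000 nM.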

Compound 3, half-maximal inhibitory concentration: 1140 nM
The estimate for compound 3 lay 1.3-fold (0.13 log units) below the measured number, within the range that was stated.
By their numbers in this assay, from the lowest: compounds 1, 3 and 2 (each within the scatter of the next).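

In this assay, putting 2,4-dichlorophenyl in place of phenyl on a saturated chain carbon bound to an oxygen gives a 1.1-fold lower number from compound 2 to compound 3 (0.03 log units; within the scatter), so the added chlorines leave the read-out level at this position. Until now, this change could be judged only indirectly through compound 1, which differs from compound 2 in more than one place; this pair isolates it with the rest of the structure held fixed. Nothing available here offers an account of why the change leaves the read-out level.

From the compounds shown here alone, it remains open whether this position would stay as insensitive with a quite different group there, such as an amine, a carboxylic acid or a longer chain ending in the same ring. Also open, going by these compounds, is whether the same exchange would read alike on the core of compound 1.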